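The source may report more compounds than this note shows. Statements on the series, on what has been measured and on what is new or still open speak of the compounds shown alone.

Measured so far in a functional assay on MGC-803 cells (Homo sapiens) for antiproliferative activity, read by CCK-8 assay, with a stated time of 72 h, tested at 8 uM; a higher number here means a stronger effect of the compound at the concentration tested, a lower number a weaker effect:
- Compound 1 `Nc1ccccc1NC(=O)c1ccc(CSC(=S)N2CCN(Cc3ccccn3)CC2)cc1` gives 65.2%
- Compound 2 `Nc1ccccc1NC(=O)c1ccc(CSC(=S)N2CCN(c3ccc(Cl)cc3)CC2)cc1` gives 17.2%
- Compound 3 `Nc1ccccc1NC(=O)c1ccc(CSC(=S)N2CCN(Cc3ccncc3)CC2)cc1` gives 79.3%

Compound 3 stands highest of these three numbers: in this assay it is a number 14.1 percentage points higher from compound 1 to compound 3 (beyond the scatter) and a number 62.1 percentage points higher from compound 2 to compound 3 (beyond the scatter), both beyond the scatter. The next compound is compound 4 `COc1ccc(N2CCN(C(=S)SCc3ccc(C(=O)Nc4ccccc4N)cc3)CC2)cc1`, which is not yet measured. The change from compound 3 to it is 4-methoxyphenyl in place of (pyridin-4-yl)methyl on an amine nitrogen in a ring. Among the compounds with values here, two measured steps bear on this. Placing 4-chlorophenyl directly on the ring nitrogen gave a number 48 percentage points lower from compound 1 to compound 2 (beyond the scatter), and going back to (pyridin-4-yl)methyl gave a number 62.1 percentage points higher from compound 2 to compound 3 (beyond the scatter). So far, an aromatic ring bound straight to that nitrogen goes with a much lower number than a ring joined through one carbon. On this basis a large drop is expected in this assay for compound 4, although a 4-methoxyphenyl group has not yet been tested and the result could differ from that seen with 4-chlorophenyl. Compound 4 is therefore estimated at 28%, with a range from 12% to 50%, a step of a number 51.3 percentage points lower from compound 3 to compound 4 (beyond the scatter).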

Compound 4, a percentage reported as inhibition, at one concentration (the size of the read-out at that concentration, not a potency): 22.9%
The estimate for compound 4 lay 5.1 percentage points above the measured number, within the range that was stated.
By their numbers in this assay, from the lowest: compounds 2 and 4 (each within the scatter of the next); then compound 1; then compound 3.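

With methoxy in place of chloro on the aromatic ring, the result is a number 5.7 percentage points higher from compound 2 to compound 4 (within the scatter), so this assay does not tell these two groups apart. The low number therefore does not belong to 4-chlorophenyl alone: 4-methoxyphenyl on the same ring nitrogen also gives a number 56.4 percentage points lower from compound 3 to compound 4 (beyond the scatter) and a number 42.3 percentage points lower from compound 1 to compound 4 (beyond the scatter), and no compound shown goes against this split. Nothing available explains this difference.

Still open is whether the higher numbers go with the one-carbon link or with the pyridine ring, as the two always occur together in the compounds shown. A benzyl group, or a pyridin-4-yl group bound straight to the ring nitrogen, would separate these two features.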